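From 2,4-dimethoxyphenyl to 2,5-dimethoxyphenyl: what to expect

A few compounds are considered here, and "the series" means these few. Any claim that something is new, unique, unknown or untested is made for them only; others in the source may bear on it.

Measured values in a functional assay on A549 cells (Homo sapiens) for cytotoxicity, read by MTT assay, with a stated time of 72 h (on this read-out lower numbers stand for stronger inhibition and higher numbers for weaker inhibition), are as follows:
- compound 1 (`COc1ccc(OC)c(/C=C/C(=O)Nc2cc3c(Nc4ccc(F)c(Cl)c4)ncnc3cc2OC)c1`) gives 11200 nM
- compound 2 (`COc1ccc(/C=C/C(=O)Nc2cc3c(Nc4ccc(F)c(Cl)c4)ncnc3cc2O[C@H]2CCOC2)c(OC)c1`) gives 9350 nM
- compound 3 (`COc1ccc(/C=C/C(=O)Nc2cc3c(Nc4ccc(F)c(Cl)c4)ncnc3cc2OC)c(OC)c1`) gives 33300 nM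

Compound 2 (9350 nM) and compound 1 (11200 nM) lie within the usual scatter of each other, and compound 3 stands clearly above both. The unmeasured compound 4 (`COc1ccc(OC)c(/C=C/C(=O)Nc2cc3c(Nc4ccc(F)c(Cl)c4)ncnc3cc2O[C@H]2CCOC2)c1`) keeps everything in compound 2 except one group (2,5-dimethoxyphenyl in place of 2,4-dimethoxyphenyl on a double-bonded chain carbon bound to a double-bonded chain carbon): 2,5-dimethoxyphenyl takes the place of 2,4-dimethoxyphenyl, with the same atoms joined differently.

The closest evidence is the same swap, seen in the opposite direction on compounds carrying methyl on the oxygen (a 3.0-fold higher number from compound 1 to compound 3 (0.47 log units; beyond the scatter)). This is a modest step, beyond the scatter. Read backwards, it points to a modest fall in the number. The other step (a 3.6-fold higher number from compound 2 to compound 3 (0.55 log units; beyond the scatter)) concerns the group on the oxygen and is of similar size. Going by the values given here, only one pair shows the phenyl swap, so whether it carries over to the oxolan-3-yl compounds is not known.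

The expected change is a modest one toward a lower number in this assay (a 2.7-fold lower number from compound 2 to compound 4 (0.43 log units; beyond the scatter)). The estimate for compound 4 is 3500 nM with an expected range from 1300 nM to 9500 nM.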

Compound 4, half-maximal inhibitory concentration: 7300 nM
Compound 4: middle estimate off by 2.1-fold (0.32 log units), on the low side; low and high end bracket the measured number.
By their numbers in this assay, from the lowest: compounds 4, 2 and 1 (each within the scatter of the next); then compound 3.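

In this assay, moving to 2,5-dimethoxyphenyl on the oxolan-3-yl compounds gives a 1.3-fold lower number from compound 2 to compound 4 (0.11 log units; within the scatter), so the step that stood beyond the scatter on the methyl compounds has no clear counterpart here, although the two steps do not differ by more than the scatter: the same change on two cores in this assay, a 3.0-fold higher number (0.47 log units; beyond the scatter) from compound 1 to compound 3 and a 1.3-fold higher number (0.11 log units; within the scatter) from compound 4 to compound 2, 2.3-fold (0.37 log units) apart, within the scatter of two such steps.
The same holds for the group on the oxygen, where a 1.5-fold lower number from compound 1 to compound 4 (0.19 log units; within the scatter) is the step on the 2,5-dimethoxyphenyl compounds, against a step beyond the scatter on the 2,4-dimethoxyphenyl compounds: the same change on two cores in this assay, a 3.6-fold higher number (0.55 log units; beyond the scatter) from compound 2 to compound 3 and a 1.5-fold higher number (0.19 log units; within the scatter) from compound 4 to compound 1, 2.3-fold (0.37 log units) apart, within the scatter of two such steps.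
Compound 1 and compound 2 each differ from compound 3 in one place, and compound 4, which carries both changes, shows no clear gain over either one.

These four compounds cannot settle whether either change truly depends on the other or whether both steps are the same within the scatter. They also leave open how the number would respond to a plain phenyl in place of the dimethoxyphenyl, or to a longer chain ending in an amine on the oxygen.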